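The source may report more compounds than this note shows. Statements on the series, on what has been measured and on what is new or still open speak of the compounds shown alone.

Series notes. The three measured compounds share one core and differ only in the aryl group on the amine nitrogen: compound 1 `Cc1ccc(NC2=CC(=O)c3nc4n(c3C2=O)[C@H]2OC[C@@H](O)[C@H]2OC4)cc1`, compound 2 `COc1cccc(NC2=CC(=O)c3c(nc4n3[C@H]3OC[C@@H](O)[C@H]3OC4)C2=O)c1` and compound 3 `CCCc1ccc(NC2=CC(=O)c3c(nc4n3[C@H]3OC[C@@H](O)[C@H]3OC4)C2=O)cc1`. In a functional assay on MGC-803 cells (Homo sapiens) for inhibition, read by sulforhodamine B assay (a lower number here means a stronger inhibitor, a higher number a weaker inhibitor), compound 1 gives 1420 nM, compound 2 gives 1790 nM and compound 3 gives 1920 nM. Compound 2 holds the second highest of the three numbers; its nearest neighbour is compound 3 and its furthest is compound 1, both within the scatter. Compound 4 `COc1ccc(NC2=CC(=O)c3c(nc4n3[C@H]3OC[C@@H](O)[C@H]3OC4)C2=O)cc1` is not yet measured and differs from compound 2 by 4-methoxyphenyl in place of 3-methoxyphenyl on an amine nitrogen. Among the compounds with values here, no measured step tests this exact change. Within the data shown here, the one measured aryl swap, a 1.1-fold higher number from compound 2 to compound 3 (0.03 log units; within the scatter), moved nothing beyond the scatter, so a small step, a 1.2-fold lower number from compound 2 to compound 4 (0.08 log units; within the scatter), is expected. Compound 4 is estimated at 1500 nM in this assay, with a range of 700 nM to 3200 nM.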

Compound 4, half-maximal inhibitory concentration: 2150 nM
Compound 4: the middle estimate sits 1.4-fold (0.16 log units) below what was measured; measured number inside the range.
By their numbers in this assay, from the lowest: compounds 1, 2, 3 and 4 (each within the scatter of the next).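

With 4-methoxyphenyl in place of 3-methoxyphenyl on the amine nitrogen, this assay gives a 1.2-fold higher number from compound 2 to compound 4 (0.08 log units; within the scatter) and so does not resolve this change of methoxy placement. Methoxy in place of propyl on an aromatic carbon gives a 1.1-fold higher number from compound 3 to compound 4 (0.05 log units; within the scatter) and is likewise unresolved, so neither change separates these aryl groups. No further data bear on this result. Still open, from the compounds shown here alone, is whether a carboxylic acid or an amine on the aryl ring, or a longer alkyl chain in place of the aryl group, would move the number beyond the scatter.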